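Trimming Compound 3 to a Single Ester: Expected Lifetime

The compounds below may be only part of what the source reports. "The series", "measured", "known", "first", "only" and "open" are said of these compounds alone.

Measured compounds:
compound 1 `N[C@@H](CCC(=O)O[C@H]1C[C@H](n2cc(F)c(=O)[nH]c2=O)O[C@@H]1CO)C(=O)O`: 0.17 h
compound 2 `CC(C)[C@H](N)C(=O)O[C@H]1C[C@H](n2cc(F)c(=O)[nH]c2=O)O[C@@H]1CO`: 0.203 h
compound 3 `N[C@@H](CC(=O)OC[C@H]1O[C@@H](n2cc(F)c(=O)[nH]c2=O)C[C@@H]1OC(=O)C[C@H](N)C(=O)O)C(=O)O`: 0.188 h

Three compounds share one core and have been examined in an ADME assay on tissue (MIA PaCa-2 cells, Homo sapiens) for pharmacokinetics; on this read-out lower numbers stand for a shorter-lived compound and higher numbers for a longer-lived compound. Compound 1 gives 0.17 h, compound 2 gives 0.203 h and compound 3 gives 0.188 h. The three numbers lie close together: compound 3 stands second highest of the three, nearest to compound 2 and furthest from compound 1, yet both gaps are within the scatter, so no order among them can be claimed.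

Compound 4 `N[C@@H](CC(=O)O[C@H]1C[C@H](n2cc(F)c(=O)[nH]c2=O)O[C@@H]1CO)C(=O)O` has not yet been measured. It differs from compound 3 in one place: hydrogen in place of (2-amino-2-carboxyethyl)carbonyl on an oxygen on a saturated carbon. For the measured compounds named here, the only measured step that changes a single group, a 1.2-fold higher number from compound 1 to compound 2 (0.08 log units; within the scatter), swaps one acyl group for another and stays within the scatter. Going by the values given here, no measured pair covers the removal of one of two such esters; what the data do show is that compounds 1, 2 and 3, carrying one or two ester groups, all sit in a narrow band in this assay.

On that basis compound 4 is expected to remain in the same band, with a step of a 1.0-fold higher number from compound 3 to compound 4 (0.00 log units; within the scatter) that is not expected to exceed the scatter. The estimate for compound 4 is 0.19 h, with a range from 0.1 h to 0.36 h.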

Compound 4, half-life: 0.535 h
The estimate for compound 4 lay 2.8-fold (0.45 log units) below the measured number; the measured number lies above the stated range.
By their numbers in this assay, from the lowest: compounds 1, 3 and 2 (each within the scatter of the next); then compound 4.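

In this assay, for the compounds shown here, hydrogen in place of (2-amino-2-carboxyethyl)carbonyl on the oxygen, which turns the ((2-amino-2-carboxyethyl)carbonyl)oxy group into hydroxy, gives a 2.8-fold higher number from compound 3 to compound 4 (0.45 log units; beyond the scatter), so this position can shift the read-out even though the earlier compounds all lay within the scatter of one another. Going by these compounds alone, the acyl group on the remaining ester also proved to matter, as 2-amino-2-carboxyethyl in place of 1-amino-2-methylpropyl on a carbonyl carbon gives a 2.6-fold higher number from compound 2 to compound 4 (0.42 log units; beyond the scatter), and amino(carboxy)methyl in place of 2-amino-2-carboxyethyl on a saturated chain carbon bound to a carbonyl carbon gives a 3.1-fold higher number from compound 1 to compound 4 (0.50 log units; beyond the scatter), whereas the only earlier single change gave a 1.2-fold higher number from compound 1 to compound 2 (0.08 log units; within the scatter). Nothing available explains why compound 4 stands apart from the other three.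

The compounds shown leave open whether a free hydroxymethyl would give a similar step with the 1-amino-2-methylpropyl ester of compound 2 or the longer chain of compound 1. They also leave open how an acetyl group on that same oxygen, or an amide in place of the remaining ester, would compare with compound 4.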